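The compounds below may be only part of what the source reports. "The series", "measured", "known", "first", "only" and "open" are said of these compounds alone.

Measured so far:
compound 1, `Cc1nc(N)nc(N[C@@H]2C[C@H](CO)[C@@H](O)[C@H]2O)c1-c1nc2ccccc2s1`: 4000 nM
compound 2, `CNc1nc(C)c(-c2nc3ccccc3s2)c(N[C@@H]2C[C@H](CO)[C@@H](O)[C@H]2O)n1`: the value for compound 2 is a limit of the assay, > 25000 nM
compound 3, `CCNc1nc(C)c(-c2nc3ccccc3s2)c(N[C@@H]2C[C@H](CO)[C@@H](O)[C@H]2O)n1`: 12000 nM

In an ADME assay on cells (Homo sapiens) for cytotoxicity, read by polymerase chain reaction, with a stated time of 3 days (on this read-out lower numbers stand for higher toxicity in this test and higher numbers for lower toxicity in this test), compound 3 stands highest of the two numbers given; the step to it from its nearest neighbour reads a 3.0-fold higher number from compound 1 to compound 3 (0.48 log units; beyond the scatter). The value for compound 2 sits at the limit (the limit of > 25000 nM in this assay, at which 1 of the 3 values shown sits), so only a bound is known there.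

Compound 4, `CCCNc1nc(C)c(-c2nc3ccccc3s2)c(N[C@@H]2C[C@H](CO)[C@@H](O)[C@H]2O)n1`, differs from compound 3 by methyl in place of hydrogen on a saturated chain carbon, two bonds along the chain from a nitrogen on an aromatic ring, so the ethylamino of compound 3 becomes propylamino. The most closely related measured step is an at least 2.0-fold lower number from compound 2 to compound 3 (0.31 log units; beyond the scatter), the same chain growth one bond nearer the ring, which lowered the number. The alkylation steps an at least 6.2-fold higher number from compound 1 to compound 2 (0.79 log units; beyond the scatter) and a 3.0-fold higher number from compound 1 to compound 3 (0.48 log units; beyond the scatter) raised the number from the unsubstituted amine, but they concern the first carbon on the nitrogen, not chain length. For compound 4 a further modest lowering, or no step beyond the scatter, is therefore expected, a 1.5-fold lower number from compound 3 to compound 4 (0.18 log units; within the scatter). Compound 4 is estimated at 8000 nM, with a likely range from 3000 nM to 25000 nM.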

Compound 4, half-maximal cytotoxic concentration: > 25000 nM
Compound 4: a limit, no number; the forecaster's own chance of this, stated with the estimate: 15%; middle value at least 3.1-fold (0.49 log units) away from the limit.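

In this assay, lengthening ethylamino to propylamino gives an at least 2.0-fold higher number from compound 3 to compound 4 (0.31 log units; beyond the scatter), opposite in direction to an at least 2.0-fold lower number from compound 2 to compound 3 (0.31 log units; beyond the scatter), so among these compounds the number does not fall steadily as the chain grows. Propyl on the nitrogen also keeps the gain over the unsubstituted amine, with an at least 6.2-fold higher number from compound 1 to compound 4 (0.79 log units; beyond the scatter), so methyl, ethyl and propyl at this position all give steps from compound 1 beyond the scatter. The step between compound 2 and compound 4 cannot be read, as both values are limits of the assay: the limit of > 25000 nM in this assay, at which 2 of the 4 values shown sit.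

As far as these compounds go, how far compound 2 and compound 4 lie past that limit stays unknown, so their order relative to each other is open. Also open, from the compounds shown here alone, is whether a longer chain such as butyl, or a branched group such as isopropyl, on the same nitrogen would give a number or sit at the limit.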